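The compounds below may be only part of what the source reports. "The series", "measured", "known", "first", "only" and "open" are said of these compounds alone.

Working notes on the bis-furan amidine series in an ADME assay on cells (Erythrocyte, Homo sapiens) for activation, read by hemolysis, with a stated time of 30 min, tested at 10 mM; a lower number here means a weaker effect, a higher number a stronger effect of the compound at the concentration tested.

Going by the values given here, compound 2 `N=C(N)c1ccc(-c2ccc(-c3ccc(Cl)cc3)o2)o1` stands highest of the three numbers measured so far, giving 97.3%. Its nearest neighbour is compound 1 `COc1ccc(-c2ccc(-c3ccc(C(=N)N)o3)o2)cc1`, which gives 71.7%; the furthest is compound 3 `N=C(N)c1ccc(-c2ccc(-c3cncc4ccccc34)s2)s1`, which gives 12.3%. Compound 3 carries a different core and a different aryl group, so only its value is noted here.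

The step now considered leads to compound 4 `N=C(N)c1ccc(-c2ccc(-c3ccccc3)o2)o1`, not yet measured. The change from compound 2 is hydrogen in place of chloro on an aromatic carbon.

Among the compounds with values here, one measured step bears on this position: a number 25.6 percentage points higher from compound 1 to compound 2 (beyond the scatter). That step shows the para group on the terminal ring matters beyond the scatter, with chloro sitting well above methoxy. Within the data shown here, no measured pair shows hydrogen at this position, so the direction of the move from chloro to hydrogen is uncertain; compound 1 shows that a group other than chloro can sit clearly lower, and the unsubstituted ring is expected to fall somewhere between the two measured neighbours. A downward step is expected for a number 17.3 percentage points lower from compound 2 to compound 4 (beyond the scatter), of modest size.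

Compound 4 is therefore estimated at 80%, within a range of 55% to 98%.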

Compound 4, a percentage reported as activity, at one concentration (the size of the read-out at that concentration, not a potency): 66.7%
Compound 4: middle estimate off by 13.3 percentage points, on the high side; measured number inside the range.
By their numbers in this assay, from the lowest: compound 3; then compounds 4 and 1 (each within the scatter of the next); then compound 2.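

In this assay, going by these compounds alone, taking chloro off the six-membered aromatic ring of carbon only and leaving hydrogen gives a number 30.6 percentage points lower from compound 2 to compound 4 (beyond the scatter), the first direct reading of what chloro itself contributes at this place on the shared core. The comparison with the unsubstituted ring then gives a number 5 percentage points lower from compound 1 to compound 4 (within the scatter), so methoxy and hydrogen cannot be told apart here, and the earlier step, a number 25.6 percentage points higher from compound 1 to compound 2 (beyond the scatter), now reads as chloro standing apart from both groups rather than as methoxy pulling the number down. Across compound 1, compound 2 and compound 4, chloro is thus the only one of the three groups that separates from the others beyond the scatter, and nothing available gives a reason for this.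

As far as these compounds go, whether this separation belongs to chloro alone or extends to other groups at the same place, such as fluoro, bromo, trifluoromethyl, an amine or a carboxylic acid, remains open. Also open, from the compounds shown here alone, is whether the same exchange of chloro for hydrogen would give a step of similar size on the core of compound 3.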